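The compounds below may be only part of what the source reports. "The series", "measured", "known", "first", "only" and "open" are said of these compounds alone.

Compound 2 `Cn1c(Cc2nn(C)c(=O)c3ccccc23)nnc1SCCCCCCCC(=O)Nc1ccc(Cl)cc1Cl` sits second highest of the three numbers measured in an assay on cells for inhibition of IL15-IL15 receptor (Homo sapiens), read by AlphaScreen, with stated times of 30 min and 1 h (a lower number here means a stronger inhibitor, a higher number a weaker inhibitor), where compound 2 gives 153000 nM. Its nearest neighbour is compound 1 `CCCOc1ccc(NC(=O)CCCCCCCSc2nnc(Cc3nn(C)c(=O)c4ccccc34)n2C)cc1`, which in this assay gives 40000 nM; the furthest is compound 3 `Cn1c(Cc2nn(C)c(=O)c3ccccc23)nnc1SCC(=O)Nc1ccc(Cl)cc1Cl`, which in this assay gives 9110000 nM.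

The step now followed leads from compound 2 to compound 4 `COc1ccc(NC(=O)CCCCCCCSc2nnc(Cc3nn(C)c(=O)c4ccccc34)n2C)cc1`, not yet measured. The change is 4-methoxyphenyl in place of 2,4-dichlorophenyl on an amide-type nitrogen: the 2,4-dichlorophenyl leaves and the 4-methoxyphenyl enters on the amide-type nitrogen whose other neighbour is the carbonyl carbon.

Going by the values given here, one measured step bears on this change. Going the other way, from a 4-propoxyphenyl to the 2,4-dichlorophenyl on the same nitrogen, a 3.8-fold higher number from compound 1 to compound 2 (0.58 log units; beyond the scatter) was seen. Compound 4 carries a 4-methoxyphenyl rather than a 4-propoxyphenyl, so the two steps are not mirror images, but both exchange the 2,4-dichlorophenyl for an alkoxyphenyl. On that basis a step in this assay from compound 2 to compound 4 toward a lower number, of a size comparable to what compound 1 showed against compound 2, is expected, and written as a 3.1-fold lower number from compound 2 to compound 4 (0.49 log units; beyond the scatter). For compound 4 in this assay the estimate is therefore 50000 nM, expected to lie between 15000 nM and 160000 nM.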

Compound 4, half-maximal inhibitory concentration: 201000 nM
Estimate against measurement, compound 4: 4.0-fold (0.60 log units) below, outside the stated range (above it).
By their numbers in this assay, from the lowest: compound 1; then compounds 2 and 4 (each within the scatter of the next); then compound 3.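

In this assay, replacing the 2,4-dichlorophenyl with the 4-methoxyphenyl on the amide-type nitrogen gives a 1.3-fold higher number from compound 2 to compound 4 (0.12 log units; within the scatter), so these two groups cannot be told apart at this position, even though only the 4-methoxyphenyl has a hydrogen-bond acceptor counted on it. The earlier step had set a 4-propoxyphenyl against the 2,4-dichlorophenyl, and this result shows that an alkoxyphenyl at this position does not by itself bring the lower number of compound 1. The two alkoxyphenyl compounds instead differ beyond the scatter, with hydrogen in place of ethyl on the saturated chain carbon bound to the oxygen on the aromatic ring giving a 5.0-fold higher number from compound 1 to compound 4 (0.70 log units; beyond the scatter), and no evidence given here accounts for either step.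

The compounds shown do not tell whether a longer chain on that oxygen, such as butoxy, would carry the number lower still or whether propoxy is particular in this respect. They also leave open how an amine or a carboxylic acid on the end of that alkoxy chain would read in this assay, and whether the gap between the propoxy and methoxy compounds would persist with a shorter chain in the rest of the molecule.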